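The compounds below may be only part of what the source reports. "The series", "measured", "known", "first", "only" and "open" are said of these compounds alone.

Measured so far:

- compound 1 `Brc1ccc(C(c2c[nH]c3ccc(Br)cc23)c2c[nH]c3ccc(Br)cc23)cc1`: 5600 nM
- compound 2 `O=[N+]([O-])c1ccc(C(c2c[nH]c3ccc(Br)cc23)c2c[nH]c3ccc(Br)cc23)cc1`: 5500 nM
- compound 3 `O=[N+]([O-])c1ccc2[nH]cc(C(c3ccc(Br)cc3)c3c[nH]c4ccc([N+](=O)[O-])cc34)c2c1`: > 100000 nM

In a functional assay on A549 cells (Homo sapiens) for inhibition, read by MTT assay, with a stated time of 48 h (on this read-out lower numbers stand for stronger inhibition and higher numbers for weaker inhibition), compound 1 gives 5600 nM. Compound 2 differs from it by nitro in place of bromo on an aromatic carbon and in this assay gives 5500 nM, so the step of a 1.0-fold lower number from compound 1 to compound 2 (0.01 log units; within the scatter) is within the scatter. For compound 3 only a limit is known in this assay, > 100000 nM, which is the limit (the limit of > 100000 nM in this assay, at which 1 of the 3 values shown sits). How the core of compound 3 differs from that of compound 1 is not broken down here.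

Compound 4 `O=[N+]([O-])c1ccc(C(c2c[nH]c3ccc([N+](=O)[O-])cc23)c2c[nH]c3ccc([N+](=O)[O-])cc23)cc1` is not yet measured. It differs from compound 3 by nitro in place of bromo on an aromatic carbon, the same change as from compound 1 to compound 2, and made at the same place. Since that change gave a 1.0-fold lower number from compound 1 to compound 2 (0.01 log units; within the scatter), the expected step is a step that the limit leaves unreadable from compound 3 to compound 4, essentially no shift. Because compound 3 only reaches the limit (the limit of > 100000 nM in this assay, at which 1 of the 3 values shown sits), compound 4 is also expected to give only a limit, with an estimated value of 150000 nM in this assay, and with a range from 30000 nM to 600000 nM.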

Compound 4, half-maximal inhibitory concentration: > 100000 nM
Compound 4: a limit, no number; the forecaster's own chance of this, stated with the estimate: 75%; the middle value is on the limit's open side.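

In this assay compound 4 gives > 100000 nM, which is a limit and not a number. Compound 3 also stands only at a limit, so no step between compound 3 and compound 4 can be read: the limit of > 100000 nM in this assay, at which 2 of the 4 values shown sit.

Still open, from the compounds shown here alone, is how far compound 3 and compound 4 lie past the limit, and whether nitro in place of bromo changes anything in this pair.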